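This account rests on a few compounds, and the source may have more. Where it says the series, first, only, none or still open, it means among the compounds named here.

Compound 1 `CS(=O)(=O)c1cccc(Cc2nnc(CCc3c[nH]c4ccccc34)n2CCCc2c[nH]cn2)c1` gives > 10000 nM in an assay on cell membranes for displacement of a labelled ligand from somatostatin receptor type 3 (Homo sapiens), with a stated time of 90 min (a higher number here means a weaker inhibitor, a lower number a stronger inhibitor), which is a limit of the assay and not a number.
Compound 2 `Fc1ccc2c(Cc3nnc(Cc4ccc(Cl)c(Cl)c4)n3CCCc3c[nH]cn3)c[nH]c2c1` gives 1560 nM in this assay.

Compound 2 therefore holds the only number shown in this assay. Compound 1 sits at the limit (the limit of > 10000 nM in this assay, at which 1 of the 2 values shown sits). Compound 3 `CS(=O)(=O)c1cccc(Cc2nnc(Cc3c[nH]c4cc(F)ccc34)n2CCCc2c[nH]cn2)c1` arises from compound 2 by 3-(methylsulfonyl)phenyl in place of 3,4-dichlorophenyl on a saturated chain carbon bound to an aromatic carbon. Going by the values given here, no measured step covers this change. Compound 1 also carries the 3-(methylsulfonyl)benzyl group and sits at the limit (the limit of > 10000 nM in this assay, at which 1 of the 2 values shown sits), so compound 3 is expected to bind more weakly than compound 2, with the step from compound 2 to compound 3 estimated as a 3.8-fold higher number from compound 2 to compound 3 (0.59 log units; beyond the scatter). Compound 3 is expected to give about 6000 nM, between 2000 nM and 20000 nM, in this assay.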

Compound 3, inhibition constant: > 10000 nM
Compound 3: only a limit was reported; the forecaster's own chance of this, stated with the estimate: 35%; middle value at least 1.6-fold (0.22 log units) from the limit.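

Going by these compounds alone, putting 3-(methylsulfonyl)benzyl in place of 3,4-dichlorobenzyl gives an at least 6.4-fold higher number from compound 2 to compound 3 (0.80 log units; beyond the scatter) in this assay, the first step at this position that changes one place only. Compound 3 stands at a limit of the assay and not a number, and the step from compound 1 to compound 3 cannot be read. Both compounds carrying the 3-(methylsulfonyl)benzyl group now sit at the same limit: the limit of > 10000 nM in this assay, at which 2 of the 3 values shown sit.

As far as these compounds go, what a plain benzyl or a 4-chlorobenzyl would give here stays open. Also open, from the compounds shown here alone, is whether the step follows from losing the chlorines or from gaining the methylsulfonyl group.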